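The source may hold more compounds than are shown below. What is called first, only, known or untested is meant among the compounds shown, and "the series" means these compounds.

In a functional assay on THP-1 cells (Homo sapiens) for cytotoxicity, read by MTT assay, with a stated time of 24 h (on this read-out lower numbers stand for stronger inhibition and higher numbers for weaker inhibition), compound 1 `CCCCCCCCCCn1cc(-c2nc3ccccc3cc2CCC)nn1` gives only a limit, > 100 ug/mL. Compound 2 `CCc1cc2ccccc2nc1-c1cn(-c2ccc(F)cc2)nn1` likewise gives only a limit in this assay, > 100 ug/mL. Where compound 2 stands is thus known only as that boundary, and the two values shown both sit at the same limit (the limit of > 100 ug/mL in this assay, at which 2 of the 2 values shown sit). Compound 3 `CCCCc1cc2ccccc2nc1-c1cn(-c2ccc(F)cc2)nn1` differs from compound 2 by ethyl in place of hydrogen on a saturated chain carbon, two bonds along the chain from an aromatic carbon. Among the compounds with values here, no measured pair shows what such a change does here, so the expected step from compound 2 to compound 3 is a step that the limit leaves unreadable from compound 2 to compound 3, none beyond the usual scatter. Compound 3 is therefore estimated at 150 ug/mL in this assay, within 50 ug/mL to 400 ug/mL.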

Compound 3, half-maximal inhibitory concentration: 78.3 ug/mL
Beside the measured number, compound 3's estimate is 1.9-fold (0.28 log units) above it, and the stated range covers the measured number.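

In this assay, compound 3, with ethyl in place of hydrogen on the saturated chain carbon two bonds along the chain from an aromatic carbon, gives 78.3 ug/mL, the first exact number among the compounds shown. The change amounts to an at least 1.2-fold lower number from compound 2 to compound 3 (0.10 log units; that floor lies within the scatter), so only a floor is known, and that floor alone does not establish a real difference. The true size of the step stays unknown because compound 2 carries only a limit: the limit of > 100 ug/mL in this assay, at which 2 of the 3 values shown sit.

As far as these compounds go, whether a longer chain such as hexyl at this carbon would lower the number further remains open. So does the effect of an amine at the end of this chain.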